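A few compounds are considered here, and "the series" means these few. Any claim that something is new, unique, unknown or untested is made for them only; others in the source may bear on it.

The measured compounds in a functional assay on MOLT-4 cells (Homo sapiens) for cytotoxicity, read by sulforhodamine B assay, with a stated time of 48 h, tested at 1 uM; on this read-out lower numbers stand for a stronger effect and higher numbers for a weaker effect at the one concentration tested:

compound 1, `COc1cc(C)cc(-c2c(-c3ccnc(-c4ccc(C(C)=O)cc4)c3)cnn2CC#N)c1`, gives 7%
compound 2, `Cc1cc(O)cc(-c2nn(CC#N)cc2-c2ccnc(-c3ccc(Oc4ccccc4)cc3)c2)c1`, gives -16%
compound 3, `COc1cc(C)cc(-c2nn(CC#N)cc2-c2ccnc(-c3ccc(N(C)C)cc3)c2)c1`, gives 13%

Among these three, compound 3 stands with the highest number, which on this read-out means the weakest effect at the single concentration tested. Its number and that of compound 1 lie within the usual scatter of each other, so no order between them can be read. Compound 2 lies beyond the scatter below compound 3, so compound 2 shows a stronger effect than compound 3.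

Compound 4, `Cc1cc(O)cc(-c2nn(CC#N)cc2-c2ccnc(-c3ccc(N(C)C)cc3)c2)c1`, has not yet been measured in this assay. It differs from compound 3 in one place: hydrogen in place of methyl on an oxygen on an aromatic ring. Among the measured compounds shown here, no pair of measured compounds differs by this change alone, so there is no measured step to lean on. Compound 2 carries the same hydroxy group as compound 4 but also differs from compound 3 elsewhere, so its value cannot be assigned to this one change. The expected step is therefore a number 6 percentage points lower from compound 3 to compound 4 (within the scatter), small, leaning slightly toward a stronger effect but not beyond the scatter. Compound 4 is expected to give about 7% in this assay, within -12% to 25%.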

Compound 4, a percentage reported as activity, at one concentration (the size of the read-out at that concentration, not a potency): 11%
For compound 4 the middle estimate is 4 percentage points below the measured one; the measured number falls inside the stated range.
By their numbers in this assay, from the lowest: compound 2; then compounds 1, 4 and 3 (each within the scatter of the next).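

In this assay, replacing methyl with hydrogen on an oxygen on an aromatic ring, which turns methoxy into hydroxy, gives a number 2 percentage points lower from compound 3 to compound 4 (within the scatter) and so no difference can be read between the two compounds; with dimethylamino on the other end of the molecule, this position accepts either group at the one concentration tested. The hydroxy group is also shared by compound 2 and compound 4, which makes a second comparison possible: dimethylamino in place of phenoxy on an aromatic carbon gives a number 27 percentage points higher from compound 2 to compound 4 (beyond the scatter) and this places the clear gap between those two compounds at that one site, not at the hydroxy group. Nothing among the available data explains why either step has the size it does.

On these data alone, it remains open whether the change from methoxy to hydroxy would stay this small in a compound carrying phenoxy in place of dimethylamino. Also open, as far as these compounds go, is how a longer chain on that oxygen, such as ethoxy, or an amine in place of the hydroxy group, would read in this assay.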